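Allyl and methoxy swap on the hydrazone aryl ring

The source may report more compounds than this note shows. Statements on the series, on what has been measured and on what is new or still open speak of the compounds shown alone.

Compound 1 `COc1ccc(/C=N/NC(=O)Nc2ccc(Oc3ccnc4cc(OCCCN5CCCCC5)c(OC)cc34)c(F)c2)cc1` gives 660 nM in a functional assay on MKN-45 cells (Homo sapiens) for cytotoxicity, read by MTT assay, with a stated time of 72 h (a higher number here means a weaker inhibitor, a lower number a stronger inhibitor), the lowest of the two numbers; compound 2 `COc1cc2c(Oc3ccc(NC(=O)N/N=C/c4ccc(N(C)C)cc4)cc3F)ccnc2cc1OCCCN1CCCCC1` gives 870 nM. Within the data shown here, the only measured step, a 1.3-fold higher number from compound 1 to compound 2 (0.12 log units; within the scatter), lies within the scatter and is the sole guide. Among the measured compounds shown here, compound 3 `C=CCc1cccc(/C=N/NC(=O)Nc2ccc(Oc3ccnc4cc(OCCCN5CCCCC5)c(OC)cc34)c(F)c2)c1OC` carries 3-allyl-2-methoxyphenyl in place of 4-methoxyphenyl on a carbon with a double bond to nitrogen, a larger change on the same ring for which no step exists. Compound 3 is therefore expected at 900 nM, between 300 nM and 2700 nM, a change of a 1.4-fold higher number from compound 1 to compound 3 (0.13 log units; within the scatter) that stays within the scatter but with wide uncertainty.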

Compound 3, half-maximal inhibitory concentration: 670 nM
The estimate for compound 3 lay 1.3-fold (0.13 log units) above the measured number, and the stated range covers the measured number.
By their numbers in this assay, from the lowest: compounds 1, 3 and 2 (each within the scatter of the next).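

In this assay, the larger 3-allyl-2-methoxyphenyl in place of 4-methoxyphenyl gives a 1.0-fold higher number from compound 1 to compound 3 (0.01 log units; within the scatter), so adding an allyl group and moving the methoxy group leaves the number within the scatter. The comparison with the dimethylamino compound gives a 1.3-fold lower number from compound 2 to compound 3 (0.11 log units; within the scatter), so all three aryl groups at this position remain within the scatter of one another. No measurement offered here explains this result.

From the compounds shown here alone, the separate contributions of the allyl and methoxy groups remain open. So does whether a carboxylic acid or a primary amine on this ring would move the number beyond the scatter.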